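Methyl for Bromo, Repeated on a Second Core

The compounds below may be only part of what the source reports. "The series", "measured", "known", "first", "only" and "open" are said of these compounds alone.

Of the compounds shown here, three have been measured in an assay on isolated protein for inhibition of Amine oxidase [flavin-containing] A (Homo sapiens), read by Amplex Red, with a stated time of 15 min, tested at 100 uM; a lower number here means less inhibition, a higher number more inhibition at the concentration tested (going by the name of the read-out). Compound 1 `CC(=O)c1ccc(OCc2cccc(C)c2)cc1` gives 32.3%. Compound 2 `CC(=O)c1ccc(OCc2cccc(Br)c2)cc1` gives 48.3%, and compound 3 `CC(=O)c1cccc(OCc2cccc(Br)c2)c1` gives 49.1%. The difference between the cores of compound 2 and compound 3 is not broken down here; their two values lie within the scatter of each other. Between compound 2 and compound 1 the change is methyl in place of bromo on an aromatic carbon, and it made a step of a number 16 percentage points lower from compound 2 to compound 1 (beyond the scatter). Compound 4 `CC(=O)c1cccc(OCc2cccc(C)c2)c1` is not yet measured; it differs from compound 3 by methyl in place of bromo on an aromatic carbon, the same change carried onto the other core. Because the step of a number 16 percentage points lower from compound 2 to compound 1 (beyond the scatter) has been seen once, for compound 4 a step of like size is expected, a number 16.1 percentage points lower from compound 3 to compound 4 (beyond the scatter). Compound 4 is accordingly estimated at 33%, between 20% and 46%.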

Compound 4, a percentage reported as inhibition, at one concentration (the size of the read-out at that concentration, not a potency): 31.1%
For compound 4 the middle estimate is 1.9 percentage points above the measured one, within the range that was stated.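

Methyl in place of bromo made a step of a number 18 percentage points lower from compound 3 to compound 4 (beyond the scatter) in this assay, so the drop seen on the first core also appeared on the second. Within the data shown here, the two steps match in size: the same change on two cores in this assay, a number 16 percentage points lower (beyond the scatter) from compound 2 to compound 1 and a number 18 percentage points lower (beyond the scatter) from compound 3 to compound 4, 2 percentage points apart, within the scatter of two such steps This shows that the change carried over between these two cores, but it covers only two cores at a single tested concentration, and it neither shows that the step would hold on a further core nor explains why it occurs.

The compounds shown carry only bromo or methyl at this place, so the outcome with a chloro, a methoxy group or an amine remains open. Also open, from the compounds shown here alone, is whether the same step would appear on a core carrying an amide in place of the ketone.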